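Trimming the Chain of Compound 2

The source may report more compounds than this note shows. Statements on the series, on what has been measured and on what is new or still open speak of the compounds shown alone.

Measured in a functional assay on PC-3 cells (Homo sapiens) for inhibition, read by MTT assay, with a stated time of 96 h; on this read-out higher numbers stand for weaker inhibition of growth and lower numbers for stronger inhibition of growth:
- compound 1 `O=C(OCc1ccccc1)SCCCCCCNC(=O)c1cc(-c2ccncc2)n[nH]1`: 15400 nM
- compound 2 `CCCC(=O)SCCCCCCNC(=O)c1cc(-c2ccncc2)n[nH]1`: 32100 nM

Of these two, compound 2 has the higher number, 32100 nM, and so the weaker inhibition of growth. Compound 3 `CCC(=O)SCCCCCCNC(=O)c1cc(-c2ccncc2)n[nH]1` has not yet been measured. It differs from compound 2 by hydrogen in place of methyl on a saturated chain carbon, two bonds along the chain from a carbonyl carbon, which turns propyl into ethyl.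

For the measured compounds named here, only one measured step bears on this: a 2.1-fold higher number from compound 1 to compound 2 (0.32 log units; beyond the scatter), a modest step, with propyl in place of benzyloxy on a carbonyl carbon. The present change is a smaller swap of groups, so no step beyond the scatter is expected in this assay, and these data give no firm direction. The expected step is a 1.1-fold lower number from compound 2 to compound 3 (0.03 log units; within the scatter). The estimate for compound 3 is 30000 nM, with an expected range of 15000 nM to 60000 nM.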

Compound 3, concentration for 50% growth inhibition: > 50000 nM
Compound 3: a limit, no number; the forecaster's own chance of this, stated with the estimate: 5%; at least 1.6-fold (0.22 log units) between middle value and limit.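

In this assay compound 3 gives only a limit of the assay, not a number: the limit of > 50000 nM in this assay, at which 1 of the 3 values shown sits.

Hydrogen in place of methyl at this position gives an at least 1.5-fold higher number from compound 2 to compound 3 (0.19 log units; that floor lies within the scatter) and so offers no sign of stronger inhibition of growth, though the true size of the step stays unknown. Ethyl in place of benzyloxy on the carbonyl carbon gives an at least 3.2-fold higher number from compound 1 to compound 3 (0.51 log units; beyond the scatter) and is a clearer loss, so among these three compounds inhibition of growth weakens from benzyloxy to propyl to ethyl, with the last step only partly resolved.

Going by these compounds, what remains open is whether a longer chain, such as pentyl, would push the number down again on this carbonyl carbon. Benzyl placed directly on the carbonyl carbon, without the oxygen of benzyloxy, could also show whether the oxygen or the benzyl part matters for this read-out.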